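Swapping the aryl group on the piperazine of a sulfonyl-lactam chain

The source may hold more compounds than are shown below. What is called first, only, known or untested is meant among the compounds shown, and "the series" means these compounds.

Measured compounds:
Compound 1 `O=C1c2ccccc2S(=O)(=O)N1CCCCCCN1CCN(c2cccc(Cl)c2Cl)CC1` — 72 nM
Compound 2 `COc1ccccc1N1CCN(CCCCCCN2C(=O)c3ccccc3S2(=O)=O)CC1` — 779 nM

Going by the values given here, in an assay on HEK293 cells for displacement of a labelled ligand from 5-hydroxytryptamine receptor 6 (Homo sapiens) (on this read-out higher numbers stand for weaker inhibition and lower numbers for stronger inhibition), compound 2 gives the highest of the two numbers recorded so far, that is the weakest binding, with compound 1 at 72 nM as its only neighbour. Among the compounds with values here, the one step seen, an 11-fold higher number from compound 1 to compound 2 (1.03 log units; beyond the scatter), is the change from 2,3-dichlorophenyl to 2-methoxyphenyl on the ring amine nitrogen. Compound 3 `O=C1c2ccccc2S(=O)(=O)N1CCCCCCN1CCN(c2ccc(Cl)cc2)CC1` carries a third group there: 4-chlorophenyl in place of 2-methoxyphenyl on an amine nitrogen in a ring. Since chlorine on that aromatic ring went with the lower number in compound 1, and compound 3 returns a chlorine-bearing phenyl, the expectation is a number below that of compound 2, though the single chlorine in a different position leaves the size uncertain. The expected step is a 3.1-fold lower number from compound 2 to compound 3 (0.49 log units; beyond the scatter), so compound 3 is estimated at 250 nM, in a range from 60 nM to 1000 nM.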

Compound 3, inhibition constant: 72 nM
For compound 3 the middle estimate is 3.5-fold (0.54 log units) above the measured one, and the stated range covers the measured number.
By their numbers in this assay, from the lowest: compounds 1 and 3 (each within the scatter of the next); then compound 2.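

In this assay, the step of an 11-fold lower number from compound 2 to compound 3 (1.03 log units; beyond the scatter) shows that a large gain does not need the 2,3-dichlorophenyl group, as 4-chlorophenyl achieves it too. The step of no change at the digits printed from compound 1 to compound 3 (within the scatter) adds that this read-out does not separate these two chlorine-bearing groups, so the second chlorine of compound 1 shows no measurable contribution here. Among these three compounds, only the one with 2-methoxyphenyl, compound 2, stands apart, and no evidence is available to explain this.

Compound 2 and compound 3 differ in both the group on the phenyl ring and where it sits, leaving open whether the higher number follows the methoxy group or its position. Comparisons with 4-methoxyphenyl, 2-chlorophenyl and unsubstituted phenyl would help separate these possibilities.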